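Amide variation at the carbonyl carbon: compound 4

This account rests on a few compounds, and the source may have more. Where it says the series, first, only, none or still open, it means among the compounds named here.

Measured in an assay on microsomes from liver for inhibition of 3-hydroxy-3-methylglutaryl-coenzyme A reductase (Rattus norvegicus); a lower number here means a stronger inhibitor, a higher number a weaker inhibitor:
compound 1 `CC(C)c1c(C(=O)N(C)Cc2ccccc2)nn(-c2ccc(F)cc2)c1CC[C@@H](O)C[C@@H](O)CC(=O)O` — 6.2 nM
compound 2 `CC(C)c1c(C(=O)N2CCC[C@H](c3ccccc3)C2)nn(-c2ccc(F)cc2)c1CC[C@@H](O)C[C@@H](O)CC(=O)O` — 2.1 nM
compound 3 `COc1cccc(CNC(=O)c2nn(-c3ccc(F)cc3)c(OC[C@@H](O)C[C@@H](O)CC(=O)O)c2C(C)C)c1` — 16 nM

Compound 3 gives the highest number of the three; compound 1 sits below it and compound 2 further below, both gaps beyond the scatter. Within the data shown here, the only step between compounds differing at a single place is a 3.0-fold lower number from compound 1 to compound 2 (0.47 log units; beyond the scatter), a change of the amine on the carbonyl carbon.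

Compound 4 `CC(C)c1c(C(=O)N(C)Cc2ccc(F)c(F)c2)nn(-c2ccc(F)cc2)c1OC[C@@H](O)C[C@@H](O)CC(=O)O` differs from compound 3 at that same carbonyl carbon: (3,4-difluorobenzyl)(methyl)amino in place of (3-methoxybenzyl)amino on a carbonyl carbon. Among the measured compounds shown here, the change bears on the amide alone, so the step from compound 1 to compound 2 is the one measured step that speaks to it; it showed that a change of the amine at this position can move the number beyond the scatter, though only modestly. Compound 1 also carries a benzyl(methyl)amino group on the carbonyl carbon and gives a lower number than compound 3, but the two differ in more than one place, so only their two values can be set side by side.

Taken together, a modest step to a lower number is expected, a 2.0-fold lower number from compound 3 to compound 4 (0.30 log units; within the scatter). For compound 4 the estimated value in this assay is 8 nM, with a range of 3 nM to 20 nM.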

Compound 4, half-maximal inhibitory concentration: 5.7 nM
The estimate for compound 4 lay 1.4-fold (0.15 log units) above the measured number, and the stated range covers the measured number.
By their numbers in this assay, from the lowest: compound 2; then compounds 4 and 1 (each within the scatter of the next); then compound 3.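

In this assay, among these compounds, the step of a 2.8-fold lower number from compound 3 to compound 4 (0.45 log units; beyond the scatter) is the first single-place step among compounds with the side chain shared by compound 3 and compound 4, so the amine on the carbonyl carbon also moves the number beyond the scatter on a side chain different from that of compound 1 and compound 2. The change is a composite one: the amide hydrogen is lost with the added methyl, and the 3-methoxybenzyl ring substitution gives way to the 3,4-difluorobenzyl pattern, yet the combined step is still only modest. No measurement shown separates these parts or accounts for the step.

Open, on these data alone, is how the step divides between the methyl on the amide nitrogen and the ring substituents, which (3,4-difluorobenzyl)amino and (3-methoxybenzyl)(methyl)amino on the same carbonyl carbon would separate. Also open, as far as these compounds go, is whether the step of a 3.0-fold lower number from compound 1 to compound 2 (0.47 log units; beyond the scatter) carries over to the side chain of compound 3 and compound 4 when 3-phenylpiperidin-1-yl is placed on the carbonyl carbon, and where a morpholin-4-yl amide would fall.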